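A few compounds are considered here, and "the series" means these few. Any claim that something is new, unique, unknown or untested is made for them only; others in the source may bear on it.

Measured compounds:
compound 1 `CC1=CC[C@H](C(C)C)c2cc(C)c(OC(=O)Nc3ccccc3)cc21` gives 100%
compound 2 `CC1=CC[C@H](C(C)C)c2cc(C)c(OC(=O)c3ccc([N+](=O)[O-])cc3)cc21` gives 16.8%
compound 3 `CC1=CC[C@H](C(C)C)c2cc(C)c(OC(=O)c3cccc(Cl)c3)cc21` gives 0.9%

These three compounds share one core and differ only in the group attached to the carbonyl carbon. In a functional assay on U-251 cells (Homo sapiens) for antiproliferative activity, read by sulforhodamine B assay, with a stated time of 48 h, tested at 50 uM (a lower number here means less inhibition, a higher number more inhibition at the concentration tested (going by the name of the read-out)), compound 1 is the high point, while compound 2 and compound 3 sit far below it: a number 83.2 percentage points lower from compound 1 to compound 2 (beyond the scatter) and a number 99.1 percentage points lower from compound 1 to compound 3 (beyond the scatter). Compound 3 stands lowest of the three numbers shown; compound 2 is its nearest neighbour, and the step between those two aromatic esters is modest, as a number 15.9 percentage points lower from compound 2 to compound 3 (beyond the scatter) shows.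

Compound 4 `COc1ccc(C(=O)Oc2cc3c(cc2C)[C@@H](C(C)C)CC=C3C)cc1` is the next member. Its difference from compound 3 is 4-methoxyphenyl in place of 3-chlorophenyl on a carbonyl carbon. Among the measured compounds shown here, the only step that bears directly on this kind of change, one substituted phenyl exchanged for another on the carbonyl carbon, is a number 15.9 percentage points lower from compound 2 to compound 3 (beyond the scatter), which was modest; the large steps both involved losing the anilino group, which compound 4 does not restore. The expectation is therefore that compound 4 stays low in this assay, with a step of a number 7.1 percentage points higher from compound 3 to compound 4 (within the scatter), small and upward at most, possibly none beyond the scatter. Compound 4 is estimated at 8%, in a range from 0% to 25%.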

Compound 4, a percentage reported as inhibition, at one concentration (the size of the read-out at that concentration, not a potency): 37%
Compound 4: the middle estimate sits 29 percentage points below what was measured; the whole stated range lies below it.
By their numbers in this assay, from the lowest: compound 3; then compound 2; then compound 4; then compound 1.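

Exchanging one substituted phenyl for another on the carbonyl carbon can matter a great deal in this assay: the change to 4-methoxyphenyl gives a large step (a number 36.1 percentage points higher from compound 3 to compound 4 (beyond the scatter)), and methoxy in place of nitro on the aromatic ring also gives a modest rise (a number 20.2 percentage points higher from compound 2 to compound 4 (beyond the scatter)). The aromatic esters therefore do not all sit near the bottom of the assay, and what the ring carries helps decide where each one lands. Even so, 4-methoxyphenyl recovers only part of the activity seen with anilino on the same carbonyl carbon (a number 63 percentage points lower from compound 1 to compound 4 (beyond the scatter)), and no independent measurement here explains the rise in compound 4.

Compound 3 and compound 4 differ in both the substituent and its printed ring number, so 3-methoxyphenyl or 4-chlorophenyl on the carbonyl carbon would be needed to separate those two changes. On these data alone, it also remains open whether a 4-methoxyanilino group would combine the features of compound 1 and compound 4, and each number comes from one concentration, so none of them gives a potency.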